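A few compounds are considered here, and "the series" means these few. Any claim that something is new, unique, unknown or untested is made for them only; others in the source may bear on it.

Working notes on the series, cytotoxicity read-out.

Compound 1 `O[C@@H]1CO[C@H]2[C@@H]1OCc1nc3cc(Br)cc(Cl)c3n12`, compound 2 `COc1c(Cl)cc2c(nc3n2[C@H]2OC[C@@H](O)[C@H]2OC3)c1Cl` and compound 3 `CS(=O)(=O)O[C@@H]1CO[C@H]2[C@@H]1OCc1nc3cc(Br)c(Br)cc3n12` share one core; compound 4 `Cc1ccc(S(=O)(=O)O[C@@H]2CO[C@H]3[C@@H]2OCc2nc4cc(Br)c(Br)cc4n23)cc1` is the unmeasured analogue of compound 3.

In an ADME assay on HEp-2 cells (Homo sapiens) for cytotoxicity, read by MTT assay, with a stated time of 60 h (on this read-out higher numbers stand for lower toxicity in this test and lower numbers for higher toxicity in this test), compound 1 gives only a limit, > 800000 nM, that is the limit of > 800000 nM in this assay, at which 1 of the 3 values shown sits, not a number. In this assay compound 2 gives 411000 nM. In this assay compound 3 gives 99500 nM, the lowest of the two numbers shown; compound 2 is the nearest number, and that gap lies beyond the scatter.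

The step from compound 3 to compound 4: 4-methylphenyl in place of methyl on a sulfonyl sulfur. Within the data shown here, no measured pair differs at a sulfonyl sulfur, so the step has no anchor among the measured compounds. The expectation is a modest move toward a lower number in this assay, possibly none beyond the scatter, as a 1.7-fold lower number from compound 3 to compound 4 (0.22 log units; within the scatter). For compound 4 the estimate in this assay is 60000 nM, within 20000 nM to 200000 nM.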

Compound 4, half-maximal cytotoxic concentration: 87500 nM
Beside the measured number, compound 4's estimate is 1.5-fold (0.16 log units) below it; the measured number falls inside the stated range.
By their numbers in this assay, from the lowest: compounds 4 and 3 (each within the scatter of the next); then compound 2. At a limit, above all of these: compound 1.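

In this assay the sulfonyl sulfur now has its first measured step, a 1.1-fold lower number from compound 3 to compound 4 (0.06 log units; within the scatter), with 4-methylphenyl in place of methyl. Among these compounds, this position therefore takes one six-membered aromatic ring of carbon only without a move beyond the scatter, something the earlier compounds could not show, as they held no pair differing here. Nothing measured in the series gives a cause for this step.

From the compounds shown here alone, whether a longer chain in place of methyl, or an amine or a carboxylic acid on the 4-methylphenyl ring, would also leave the number within the scatter stays open. Compound 3 and compound 4 each differ from compound 1 and compound 2 in more than one place, so the part played by the sulfonyl group itself cannot be read from these compounds.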